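This account rests on a few compounds, and the source may have more. Where it says the series, first, only, none or still open, it means among the compounds named here.

Measured in a functional assay for inhibition, with Homo sapiens as the target; on this read-out lower numbers stand for tighter binding and higher numbers for weaker binding:

- compound 1 `COc1ccc(OC(C)(C)C2OCC(C/C=C\CCC(=O)O)C(c3cccnc3)O2)cc1`: 302 nM
- compound 2 `CC(C)(Oc1ccc(F)cc1[N+](=O)[O-])C1OCC(C/C=C\CCC(=O)O)C(c2cccnc2)O1`: 2.51 nM

Of these two compounds, compound 2 has the lower number, 2.51 nM, and so the tighter binding. The next compound to consider is compound 3 `CC(C)(C1OCC(C/C=C\CCC(=O)O)C(c2cccnc2)O1)S(=O)(=O)c1ccccc1`, which has not yet been measured. Going from compound 2 to compound 3 makes this structural change: a group of 9 heavy atoms (6 carbon, 2 oxygen, 1 sulfur; one six-membered aromatic ring of carbon only) in place of a group of 11 heavy atoms (6 carbon, 1 nitrogen, 3 oxygen, 1 fluorine; one six-membered aromatic ring of carbon only), on a saturated chain carbon bound to two saturated chain carbons and a saturated ring carbon.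

For the measured compounds named here, only one measured step bears on this change: a 120-fold lower number from compound 1 to compound 2 (2.08 log units; beyond the scatter). That step is large and lies beyond the scatter. Going by the values given here, it shows that altering this part of the molecule can shift the number substantially, although it swapped only one substituted phenyl group for another. Among the compounds with values here, no measured compound carries phenylsulfonyl, so the data give no direct guide to this replacement. Compound 2 is also the lowest value seen so far, so a rise seems more likely than a further fall, though the size is very uncertain.

The expected change is a 12-fold higher number from compound 2 to compound 3 (1.08 log units; beyond the scatter), probably smaller than the step measured. For compound 3 the estimated value is 30 nM, with an expected range of 4 nM to 250 nM.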

Compound 3, dissociation constant: 3160 nM
Compound 3: the middle estimate sits 110-fold (2.02 log units) below what was measured; the measured number lies above the stated range.
By their numbers in this assay, from the lowest: compound 2; then compound 1; then compound 3.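

In this assay, phenylsulfonyl at this saturated chain carbon gives a 1300-fold higher number from compound 2 to compound 3 (3.10 log units; beyond the scatter), and it also compares poorly with the weaker of the two phenoxy-type compounds, with a 10-fold higher number from compound 1 to compound 3 (1.02 log units; beyond the scatter). For the compounds shown here, the earlier step showed only that the number responds strongly when one substituted phenoxy group replaces another; this result shows that a phenyl ring attached through a sulfonyl group can do worse than both, leaving compound 3 with the highest number and so the weakest binding of the three. Nothing available here explains this loss, so the data record the size of the change but not its cause.

Phenylsulfonyl differs from the groups it replaces in two ways at once, as it has a sulfonyl link in place of the oxygen and a ring without substituents, so the compounds shown cannot separate these two changes. Going by these compounds, a plain phenoxy group would address the ring substituents, and a phenylamino group would address the link, so how much each change contributes remains open.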